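One Stereocentre Flipped on a Naphthyl-Bearing Lactone

The source may hold more compounds than are shown below. What is called first, only, known or untested is meant among the compounds shown, and "the series" means these compounds.

Measured so far in the cytotoxicity test:
compound 1, `C/C=C1\C(=O)O[C@@H](c2ccc([N+](=O)[O-])cc2)[C@H]1C`: 117%
compound 2, `C=C1C(=O)O[C@H](c2ccc3ccccc3c2)[C@H]1C`: 1%
compound 3, `C=C1C(=O)O[C@@H](c2ccc3ccccc3c2)[C@H]1c1ccccc1`: 27%

Three compounds have been run in a functional assay on BXPC-3 cells (Homo sapiens) for cytotoxicity, read by MTT assay, with a stated time of 72 h, tested at 10 uM; on this read-out higher numbers stand for a weaker effect at the one concentration tested and lower numbers for a stronger effect. In this assay compound 1 gives 117%, compound 2 gives 1%, and compound 3 gives 27%. Compound 3 stands second highest of the three numbers. Its nearest neighbour is compound 2, whose number lies lower by an amount beyond the usual scatter; its furthest is compound 1, whose number lies higher by an amount far beyond the scatter. Compound 3 thus shows a clear effect, though a weaker one than compound 2.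

Compound 4, `C=C1C(=O)O[C@H](c2ccc3ccccc3c2)[C@H]1c1ccccc1`, is the next step. Compared with compound 3: the two compounds have the same atoms and bonds and differ only in configuration as drawn: 1 of 2 stereo elements differ; a stereocentre at a saturated ring carbon is drawn R in compound 3 and S in compound 4. Within the data shown here, no pair of measured compounds differs in only one place, so nothing among them shows how large such a change in configuration tends to be here. A change in configuration alone can leave the number almost untouched or shift it a good deal, and either direction is possible. The step expected here is a number 8 percentage points higher from compound 3 to compound 4 (within the scatter), only a mild weakening, with wide uncertainty. Compound 4 is therefore expected to give about 35%, somewhere between 5% and 75%.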

Compound 4, a percentage reported as activity, at one concentration (the size of the read-out at that concentration, not a potency): 1%
Estimate against measurement, compound 4: 34 percentage points above; the measured number lies below the stated range.
By their numbers in this assay, from the lowest: compounds 2 and 4 (each within the scatter of the next); then compound 3; then compound 1.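

In this assay, among these compounds, redrawing a single saturated ring carbon from R to S gives a number 26 percentage points lower from compound 3 to compound 4 (beyond the scatter), which is the first sign that configuration at this position can by itself alter the read-out. No other structural change accompanies this shift, so it can be assigned to the flipped stereocentre: the fact that compounds 3 and 4 differ only in the configuration as drawn. Phenyl in place of methyl on a saturated ring carbon gives no change at the digits printed from compound 2 to compound 4 (within the scatter), so with the configuration drawn in these two compounds, this exchange of groups leaves no visible mark on the read-out, whereas the stereocentre flip does.

From the compounds shown here alone, whether a methyl on that ring carbon would respond to the same flip as the phenyl does stays open, as does the effect of a longer chain, an amine or a carboxylic acid there. Going by these compounds, compound 2 and compound 4 also cannot be told apart by a reading at one concentration, so any difference in the strength of their effect at other concentrations, and any behaviour in other cell lines, remains unknown.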